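Swapping a Piperidine Substituent on a Pyridine Amide Core

The source may report more compounds than this note shows. Statements on the series, on what has been measured and on what is new or still open speak of the compounds shown alone.

Compound 1 `CC(C(=O)NCc1ccc(C(F)(F)F)nc1NCc1ccccc1)c1ccc(NS(C)(=O)=O)c(F)c1`, in a functional assay on CHO-K1 cells for antagonist activity at transient receptor potential cation channel subfamily V member 1 (Homo sapiens), read by FLIPR; a higher number here means a weaker inhibitor, a lower number a stronger inhibitor: 203 nM
Compound 2 `CC(C(=O)NCc1ccc(C(F)(F)F)nc1N1CCC(C(=O)c2ccc(F)cc2)CC1)c1ccc(NS(C)(=O)=O)c(F)c1`, in this assay: 990 nM

Compound 2 has the highest number of the two in this assay; its nearest neighbour is compound 1, whose number lies beyond the scatter below it. Compound 3 `CC(C(=O)NCc1ccc(C(F)(F)F)nc1N1CCC(C(F)(F)F)CC1)c1ccc(NS(C)(=O)=O)c(F)c1` differs from compound 2 in one place: trifluoromethyl in place of (4-fluorophenyl)carbonyl on a saturated ring carbon. Within the data shown here, no measured pair shows this change, so its size is unknown. Since a much smaller group enters, compound 3 is expected to shift toward lower numbers by a modest step, a 2.0-fold lower number from compound 2 to compound 3 (0.30 log units; within the scatter), though a step no larger than the scatter would not surprise. For compound 3 the estimated value in this assay is 500 nM, with a range from 150 nM to 2000 nM.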

Compound 3, half-maximal inhibitory concentration: 31 nM
For compound 3 the middle estimate is 16-fold (1.21 log units) above the measured one, outside the stated range (below it).
By their numbers in this assay, from the lowest: compound 3; then compound 1; then compound 2.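

In this assay the group on this saturated ring carbon matters greatly: trifluoromethyl in place of (4-fluorophenyl)carbonyl gives a large change (a 32-fold lower number from compound 2 to compound 3 (1.50 log units; beyond the scatter)). The substituted piperidine can also outdo the simple side chain, as 4-(trifluoromethyl)piperidin-1-yl in place of benzylamino on an aromatic carbon gives a modest gain (a 6.5-fold lower number from compound 1 to compound 3 (0.82 log units; beyond the scatter)). Nothing available explains either step. The compounds shown leave open whether the fluorine atoms are needed at all, or whether any small group would serve. A methyl group or a nitrile on the same ring carbon would help to separate these possibilities.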